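Chloro for fluoro: from compound 2 to compound 3

A few compounds are considered here, and "the series" means these few. Any claim that something is new, unique, unknown or untested is made for them only; others in the source may bear on it.

Within the data shown here, in a functional assay on SW480 cells (Homo sapiens) for antiproliferative activity, read by MTT assay, with a stated time of 48 h (on this read-out lower numbers stand for stronger inhibition and higher numbers for weaker inhibition), compound 2 (`CCCCCCC(CCO)n1cnc2c(Cl)nc(F)nc21`) gives 12900 nM, the lower of the two numbers so far. Compound 1 (`CCCCC(CCO)n1cnc2c(Cl)nc(Cl)nc21`) gives 30900 nM, a gap beyond the usual scatter. Compound 3 (`CCCCCCC(CCO)n1cnc2c(Cl)nc(Cl)nc21`) is still unmeasured and carries chloro in place of fluoro on an aromatic carbon, between two ring nitrogen atoms (chloro in place of fluoro on an aromatic carbon). Among the measured compounds shown here, no measured pair isolates this change. A step within the scatter is expected in this assay, with no firm direction. The estimated change is a 1.1-fold higher number from compound 2 to compound 3 (0.04 log units; within the scatter). For compound 3 the expected value is 14000 nM, with an estimated range of 6000 nM to 32000 nM.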

Compound 3, half-maximal inhibitory concentration: 12400 nM
Compound 3: middle estimate off by 1.1-fold (0.05 log units), on the high side, within the range that was stated.
By their numbers in this assay, from the lowest: compounds 3 and 2 (each within the scatter of the next); then compound 1.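

In this assay chloro and fluoro on an aromatic carbon, between two ring nitrogen atoms, cannot be told apart (a 1.0-fold lower number from compound 2 to compound 3 (0.02 log units; within the scatter)), so this position tolerates either halogen with the chain of compound 2. Among these compounds, the chain carries the only step beyond the scatter: ethyl in place of hydrogen on a saturated chain carbon, five bonds along the chain from an aromatic nitrogen, gives a 2.5-fold lower number from compound 1 to compound 3 (0.40 log units; beyond the scatter), a modest step. No data on hand explain either step. As far as these compounds go, whether an amine or a methoxy group at that aromatic carbon would read the same remains open, as does the effect of a longer chain than that of compound 3.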